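A few compounds are considered here, and "the series" means these few. Any claim that something is new, unique, unknown or untested is made for them only; others in the source may bear on it.

Three compounds share one core and differ only in the two aryl groups on the five-membered ring. Compound 1 `CC(=O)Oc1ccc(N2C(=O)/C(=C/N3N=C(c4ccc(Cl)cc4)CC3c3ccc(Cl)cc3)SC2=S)cc1` carries two 4-chlorophenyl groups. Among the compounds with values here, in a functional assay on HL-60 cells (Homo sapiens) for antiproliferative activity, read by MTT assay, with a stated time of 72 h (on this read-out lower numbers stand for stronger inhibition and higher numbers for weaker inhibition), compound 1 gives only a limit, > 10000 nM, and it is the single value sitting at the limit of > 10000 nM in this assay, at which 1 of the 2 values shown sits. Within the data shown here, compound 2 `CC(=O)Oc1ccc(N2C(=O)/C(=C/N3N=C(c4ccc5ccccc5c4)CC3c3ccccc3O)SC2=S)cc1` pairs a naphthalen-2-yl group with a 2-hydroxyphenyl group, and in this assay compound 2 gives 500 nM, the only actual number among the values so far. Compound 3 `CC(=O)Oc1ccc(N2C(=O)/C(=C/N3N=C(c4ccc5ccccc5c4)CC3c3ccc(Cl)cc3)SC2=S)cc1` has not yet been measured. It differs from compound 2 by 4-chlorophenyl in place of 2-hydroxyphenyl on a saturated ring carbon. Among the measured compounds shown here, no measured pair reproduces this single change, so the size of the step is open. The step from compound 2 to compound 3 is expected to go toward weaker inhibition by a 6.0-fold higher number from compound 2 to compound 3 (0.78 log units; beyond the scatter), the expectation resting on compound 1 also bearing 4-chlorophenyl on a saturated ring carbon. Compound 3 is accordingly estimated at 3000 nM, within 800 nM to 12000 nM.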

Compound 3, half-maximal inhibitory concentration: 1800 nM
Compound 3: middle estimate off by 1.7-fold (0.22 log units), on the high side; low and high end bracket the measured number.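

In this assay, the saturated ring carbon now has its first reading for a single change with naphthalen-2-yl held constant: 4-chlorophenyl in place of 2-hydroxyphenyl gives a 3.6-fold higher number from compound 2 to compound 3 (0.56 log units; beyond the scatter), so the group at this position affects inhibition by more than the usual scatter. With 4-chlorophenyl held on that saturated carbon, naphthalen-2-yl in place of 4-chlorophenyl on the carbon with a double bond to nitrogen gives an at least 5.5-fold lower number from compound 1 to compound 3 (0.74 log units; beyond the scatter), which shows that the second aryl position also counts and that 4-chlorophenyl on the saturated carbon still allows a measurable value. The value of compound 1 is a limit and not a number, so this second step gives only a minimum size: the limit of > 10000 nM in this assay, at which 1 of the 3 values shown sits.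

The step from compound 2 to compound 3 swaps both the substituent and its place on the phenyl ring, so these compounds cannot tell whether the hydroxyl group itself or its location matters; a plain phenyl, 4-hydroxyphenyl or 2-chlorophenyl group at this carbon would separate the two. As far as these compounds go, it also remains open whether 2-hydroxyphenyl would have the same effect when paired with 4-chlorophenyl on the carbon with a double bond to nitrogen.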